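Adding fluoro to compound 3: an expected step

This account rests on a few compounds, and the source may have more. Where it says the series, first, only, none or still open, it means among the compounds named here.

compound 1 `O=C(Nc1cccc(OCc2ccccc2)c1)C1CCCNC1` gives 128000 nM
compound 2 `N=C(N)N1CCCC(C(=O)Nc2cccc(OCc3ccc(F)cc3)c2)C1` gives 274000 nM
compound 3 `O=C(Nc1cccc(OCc2ccccc2)c1)C1CCNCC1` gives 229000 nM

In a functional assay on a cell-free system (Platelet, plasma, Homo sapiens) for inhibition (on this read-out higher numbers stand for weaker inhibition and lower numbers for stronger inhibition), compound 3 gives 229000 nM, the second highest of the three numbers, yet within the scatter of both compound 1 and compound 2. The next compound to be tested is compound 4 `O=C(Nc1cccc(OCc2ccc(F)cc2)c1)C1CCNCC1`. It differs from compound 3 by one change (fluoro in place of hydrogen on an aromatic carbon), fluoro in place of hydrogen on an aromatic carbon, which turns benzyl into 4-fluorobenzyl.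

Going by the values given here, no measured step isolates this change. Among the compounds with values here, the one step available, a 1.8-fold higher number from compound 1 to compound 3 (0.25 log units; within the scatter), has piperidin-4-yl in place of piperidin-3-yl, so it concerns another place and stays within the scatter. Within the data shown here, it shows only that this single change left the number within the scatter. The closest evidence is compound 2, which also carries 4-fluorobenzyl and gives 274000 nM. That value lies within the scatter of compound 3, although compound 2 also differs from compound 3 elsewhere. Nothing measured therefore points to a real shift in either direction.

The expected change is a 1.1-fold lower number from compound 3 to compound 4 (0.04 log units; within the scatter), which means no step beyond the scatter. The estimate for compound 4 is 210000 nM, with an expected range from 100000 nM to 420000 nM.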

Compound 4, half-maximal inhibitory concentration: 68000 nM
Beside the measured number, compound 4's estimate is 3.1-fold (0.49 log units) above it; measured number outside the range, below it.
By their numbers in this assay, from the lowest: compounds 4, 1, 3 and 2 (each within the scatter of the next, the first and the last beyond it).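

In this assay, going by these compounds alone, 4-fluorobenzyl in place of benzyl gives a 3.4-fold lower number from compound 3 to compound 4 (0.53 log units; beyond the scatter), so a single fluoro on this aromatic carbon, para to a large group, moves the number beyond the scatter, which the one earlier step, a change elsewhere in the molecule, did not do. The step that changes the group on the carbonyl carbon while 4-fluorobenzyl stays in place gives a 4.0-fold lower number from compound 2 to compound 4 (0.61 log units; beyond the scatter), which shows that the number also answers to that group when the fluoro is present. No measurement shown here accounts for the effect of this fluoro.

The compounds shown carry only hydrogen or fluoro at this position, so it stays open whether chloro, methyl or methoxy there would move the number in the same direction or by a similar size. From the compounds shown here alone, it also stays open whether 4-fluorobenzyl in place of benzyl would lower the number on compound 1, which carries piperidin-3-yl, as it does on compound 3.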